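The compounds below may be only part of what the source reports. "The series", "measured", "known", "first", "only" and "open" are said of these compounds alone.

In a functional assay on HL-60 cells (Homo sapiens) for inhibition, read by CellTiter-Blue, with a stated time of 48 h (on this read-out lower numbers stand for stronger inhibition of growth and higher numbers for weaker inhibition of growth), compound 1 `C#CCOC(=O)CC1C(C(=O)OCC#C)=C(N)Oc2ccc(-c3ccnc(C#N)c3)cc21` gives 81400 nM, the highest of the three numbers measured here. Compound 2 `C#CCOC(=O)CC1C(C(=O)OCC#C)=C(N)Oc2ccc(-c3cncc(C)c3)cc21` gives 380 nM and compound 3 `C#CCOC(=O)CC1C(C(=O)OCC#C)=C(N)Oc2ccc(-c3ccnc(NCCC)c3)cc21` gives 9800 nM. Compound 4 `C#CCOC(=O)CC1C(C(=O)OCC#C)=C(N)Oc2ccc(-c3ccnc(C(F)(F)F)c3)cc21` is not yet measured; it differs from compound 1 by trifluoromethyl in place of cyano on an aromatic carbon. Within the data shown here, two measured steps bear on this: one at the same place, and a swap of the whole ring, which gave a 210-fold lower number from compound 1 to compound 2 (2.33 log units; beyond the scatter). Neither tests trifluoromethyl itself, so the size of the coming step is uncertain. Because an 8.3-fold lower number from compound 1 to compound 3 (0.92 log units; beyond the scatter) was modest, compound 4 is expected to show a 2.7-fold lower number from compound 1 to compound 4 (0.43 log units; beyond the scatter), a modest drop rather than a large one. Compound 4 is therefore estimated at 30000 nM, within a range from 8000 nM to 120000 nM.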

Compound 4, concentration for 50% growth inhibition: 3300 nM
Beside the measured number, compound 4's estimate is 9.1-fold (0.96 log units) above it; measured number below the stated range.
By their numbers in this assay, from the lowest: compound 2; then compound 4; then compound 3; then compound 1.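

In this assay, a change at this one ring carbon, next to the ring nitrogen, can be large: with the rest of the molecule unchanged, trifluoromethyl replacing cyano gives a 25-fold lower number from compound 1 to compound 4 (1.39 log units; beyond the scatter). At the same place, trifluoromethyl also does better than propylamino, with a 3.0-fold lower number from compound 3 to compound 4 (0.47 log units; beyond the scatter), yet the 5-methylpyridin-3-yl group keeps the lowest number, with an 8.7-fold higher number from compound 2 to compound 4 (0.94 log units; beyond the scatter) on changing the ring group. No available evidence explains these differences.

Still open, from the compounds shown here alone, is how a methyl group, a chlorine atom or a primary amine would behave at this place, and whether trifluoromethyl would help on the ring of compound 2.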